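Replacing the 4-(thiophen-3-yl)phenyl group of compound 1

A few compounds are considered here, and "the series" means these few. Any claim that something is new, unique, unknown or untested is made for them only; others in the source may bear on it.

Measured in a functional assay on K562 cells (Homo sapiens) for inhibition, with a stated time of 72 h; on this read-out higher numbers stand for weaker inhibition and lower numbers for stronger inhibition:
compound 1 (`NC1CCC(Nc2nc(NCc3ccc(-c4ccsc4)cc3)c3ncn(C4CCCC4)c3n2)CC1`): 150 nM
compound 2 (`OC1CCC(Nc2nc(NCc3ccc(-c4ccco4)nc3)c3ncn(C4CCCC4)c3n2)CC1`): 303 nM
compound 3 (`NC1CCC(Nc2nc(NCc3ccc(-c4ccccc4O)cc3)c3ncn(C4CCCC4)c3n2)CC1`): 2610 nM

Compound 1 holds the lowest of these three numbers, with compound 2 nearest to it and compound 3 furthest away. Compound 4 (`Nc1ccccc1CNc1nc(NC2CCC(N)CC2)nc2c1ncn2C1CCCC1`) has not yet been measured. Its difference from compound 1 is 2-aminophenyl in place of 4-(thiophen-3-yl)phenyl on a saturated chain carbon bound to a nitrogen on an aromatic ring, a swap that removes the whole of the 4-(thiophen-3-yl)phenyl group.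

Among the compounds with values here, only one measured step bears on this swap, and it is not the same change. It is a 17-fold higher number from compound 1 to compound 3 (1.24 log units; beyond the scatter), with 2-hydroxyphenyl in place of thiophen-3-yl on an aromatic carbon. That step is large, and it shows that altering this part of compound 1 can cost much of its inhibition. Within the data shown here, no measured compound shows the 2-aminophenyl group itself, so the evidence is thin and the range must stay wide. On that single precedent, the expected change is a large one toward weaker inhibition, and the estimated step is a 12-fold higher number from compound 1 to compound 4 (1.08 log units; beyond the scatter) in this assay, of roughly similar size. For compound 4 the estimated value is 1800 nM, with an expected range from 450 nM to 7000 nM as the likely bounds.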

Compound 4, half-maximal inhibitory concentration: 4040 nM
Compound 4: middle estimate off by 2.2-fold (0.35 log units), on the low side; measured number inside the range.
By their numbers in this assay, from the lowest: compound 1; then compound 2; then compounds 3 and 4 (each within the scatter of the next).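

Compound 4 shows that the sensitivity at this end of compound 1 is not confined to the thiophen-3-yl ring: in this assay, removing the whole of the 4-(thiophen-3-yl)phenyl group and placing 2-aminophenyl on the saturated chain carbon gives a 27-fold higher number from compound 1 to compound 4 (1.43 log units; beyond the scatter). Within the data shown here, until now, the only single-place change at this end had kept the inner phenyl ring and altered only the group on its aromatic carbon, so the cost of replacing both rings with one had not been seen. Both single-place changes to compound 1 now point toward weaker inhibition, and no measurement shown gives a reason for the size of either step.

The swap in compound 4 shortens the group to one six-membered aromatic ring and adds an amine at once, so the compounds shown leave open how much of the step belongs to each change. A plain phenyl group at the same place, carrying no amine, would separate the two, and whether any single ring there can approach the inhibition of compound 1 also remains unsettled.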